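A methoxy step repeated across two cores

A few compounds are considered here, and "the series" means these few. Any claim that something is new, unique, unknown or untested is made for them only; others in the source may bear on it.

The study sets two cores side by side. Compound 1 `CCOC(=O)c1c(C)cc2cnn(-c3cccc(OC)c3)c(=O)c2c1C` carries the first core. In a functional assay (plasma) for inhibition, with Oryctolagus cuniculus as the target (a lower number here means that less compound is needed, a higher number that more compound is needed for the effect), compound 1 gives only a limit, >= 50 uM. Compound 2 `CCOC(=O)c1c(C)cc2cnn(-c3ccc(OC)c(OC)c3)c(=O)c2c1C` differs from compound 1 in one place: methoxy in place of hydrogen on an aromatic carbon In this assay compound 2 likewise gives only a limit, >= 50 uM. The step that the two limits leave unreadable from compound 1 to compound 2 cannot be read because both values sit at the limit of >= 50 uM in this assay, at which 2 of the 3 values shown sit.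

Compound 3 `COc1cc2cnn(-c3ccccc3)c(=O)c2cc1OC` carries a second core; how it differs from compound 1 is not broken down here. In this assay compound 3 gives only a limit, >= 100 uM, which is the limit of >= 100 uM in this assay, at which 1 of the 3 values shown sits. Compound 4 `COc1ccc(-n2ncc3cc(OC)c(OC)cc3c2=O)cc1` has not yet been measured and differs from compound 3 in one place: methoxy in place of hydrogen on an aromatic carbon This is the same kind of change as that from compound 1 to compound 2, but not the same: there the entering methoxy sat ortho to a methoxy group and para to a large group, here it is only para to a large group.

With the earlier step unreadable, the expected step of a number no higher from compound 3 to compound 4 (the limit leaves the size open) in this assay rests only on compound 3 sitting at the limit of >= 100 uM in this assay, at which 1 of the 3 values shown sits, and is estimated to be small. Compound 4 is expected to give about 100 uM, between 50 uM and 300 uM, most likely again reported as a limit.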

Compound 4, concentration for half-maximal effect: >= 100 uM
Compound 4 was reported as a limit; the forecaster's own chance of this, stated with the estimate: 80%; the middle value sits exactly at the limit.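

In this assay compound 3 and compound 4 both give only a limit, so the step between them cannot be read: the limit of >= 100 uM in this assay, at which 2 of the 4 values shown sit.

The compounds shown leave open whether methoxy in place of hydrogen on an aromatic carbon changes the concentration for half-maximal effect in either core, and what any of the four compounds would give as a number.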